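A few compounds are considered here, and "the series" means these few. Any claim that something is new, unique, unknown or untested is made for them only; others in the source may bear on it.

Measured in an in vitro ADME assay on microsomes from liver (Homo sapiens) for pharmacokinetics, read by LC-MS, with a stated time of 10 min, tested at 1 uM; on this read-out lower numbers stand for slow clearance and higher numbers for fast clearance:
- compound 1 `CN1C[C@H](C(=O)Nc2ccccc2)[C@@H](c2ccc(/C=C/C(=O)Nc3ccccc3N)cc2)C1`: 7 mL/min/kg
- compound 2 `CN1C[C@H](C(=O)Nc2ccc(C#N)cc2)[C@@H](c2ccc(/C=C/C(=O)Nc3ccccc3N)cc2)C1`: 1 mL/min/kg
- compound 3 `Cc1cccc(NC(=O)[C@H]2CN(C)C[C@@H]2c2ccc(/C=C/C(=O)Nc3ccccc3N)cc2)c1`: 14 mL/min/kg

Compound 3 stands at 14 mL/min/kg. Its nearest neighbour on these numbers gives a 2.0-fold higher number from compound 1 to compound 3 (0.30 log units; within the scatter), while its furthest gives a 14-fold higher number from compound 2 to compound 3 (1.15 log units; beyond the scatter).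

The next molecule, compound 4 `COc1cccc(NC(=O)[C@H]2CN(C)C[C@@H]2c2ccc(/C=C/C(=O)Nc3ccccc3N)cc2)c1`, carries methoxy in place of methyl on an aromatic carbon, meta to a large group: methoxy in place of methyl on an aromatic carbon. Among the compounds with values here, no measured compound carries a methoxy group, so only related steps can guide the expectation. Methyl in place of hydrogen stayed within the scatter, at a 2.0-fold higher number from compound 1 to compound 3 (0.30 log units; within the scatter). Cyano in place of hydrogen went beyond it, at a 7.0-fold lower number from compound 1 to compound 2 (0.85 log units; beyond the scatter), so a change on this ring can matter in this assay. That cyano step is a different swap, however, and gives no direction for this one.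

The expected result is no change at the digits printed from compound 3 to compound 4 (within the scatter), with no step beyond the scatter. For compound 4 the estimated clearance is 14 mL/min/kg, within an expected range of 6 mL/min/kg to 32 mL/min/kg.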

Compound 4, clearance: 14 mL/min/kg
For compound 4 middle estimate and measured number coincide at the digits printed; the range from low to high includes it.
By their numbers in this assay, from the lowest: compound 2; then compounds 1, 3 and 4 (each within the scatter of the next).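

In this assay, methoxy in place of methyl on this aromatic carbon gives no change at the digits printed from compound 3 to compound 4 (within the scatter), and methoxy in place of hydrogen gives a 2.0-fold higher number from compound 1 to compound 4 (0.30 log units; within the scatter), so at this place, meta to a large group, neither step goes beyond the scatter even with an oxygen added. By contrast, 3-methoxyphenyl in place of 4-cyanophenyl gives a 14-fold higher number from compound 2 to compound 4 (1.15 log units; beyond the scatter), showing that the separation of compound 2 from the others also holds against a methoxy compound, although that step changes both the group and its place on the ring. Nothing shown here gives a reason for these numbers.

Still open, going by these compounds, is whether a nitrile at the place held by the methoxy would give a number like that of compound 2. Also open, on these data alone, is how an amine or a carboxylic acid at that place would read.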